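Thromboxane synthase inhibitors: pyridyl heptenoic acids and an ester

The source may report more compounds than this note shows. Statements on the series, on what has been measured and on what is new or still open speak of the compounds shown alone.

Measured so far:
compound 1 `O=C(O)CCCC/C=C\c1cccnc1` — 250 nM
compound 2 `CCOC(=O)CCCC/C=C(\c1ccccc1)c1cccnc1` — 600 nM
compound 3 `O=C(O)CCCC/C=C(\c1cccnc1)c1cccc(Br)c1` — 180 nM

In an assay (Equus caballus) for inhibition of Thromboxane-A synthase (Homo sapiens), using microsomes (a higher number here means a weaker inhibitor, a lower number a stronger inhibitor), compound 2 gives the highest of the three numbers. Compound 1 sits lower than compound 2 by a gap beyond the scatter, and compound 3 lower still, also beyond the scatter. Among the compounds with values here, compound 2 is the only member carrying an (ethoxycarbonyl)methyl end on its chain; compound 1 and compound 3 both end in a free carboxy group.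

Compound 4 `C=CCC(CCC/C=C(\c1ccccc1)c1cccnc1)C(=O)O` has not been measured in this assay. It differs from compound 2 in one place: 1-carboxybut-3-en-1-yl in place of (ethoxycarbonyl)methyl on a saturated chain carbon, three bonds along the chain from a double-bonded chain carbon. The entering group brings one hydrogen-bond donor where the leaving group had none, and a second double bond outside the aromatic rings.

Within the data shown here, no step between measured compounds isolates this change. The comparison of compound 2 with compound 1 and compound 3 suggests the carboxy-ended members run lower in this assay, though that rests on three compounds only and no single-point pairing. A downward step beyond the scatter is expected; the estimate means a step of a 4.0-fold lower number from compound 2 to compound 4 (0.60 log units; beyond the scatter). Compound 4 is expected to give about 150 nM, with a range from 50 nM to 500 nM.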

Compound 4, half-maximal inhibitory concentration: 50 nM
Compound 4: middle estimate off by 3.0-fold (0.48 log units), on the high side; low and high end bracket the measured number.
By their numbers in this assay, from the lowest: compound 4; then compounds 3 and 1 (each within the scatter of the next); then compound 2.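

Within the data shown here, on a saturated chain carbon, three bonds along the chain from a double-bonded chain carbon, the change from (ethoxycarbonyl)methyl to 1-carboxybut-3-en-1-yl gives the first single-place step: in this assay it is a 12-fold lower number from compound 2 to compound 4 (1.08 log units; beyond the scatter), a large step beyond the scatter. The earlier compounds shown here offered only an unpaired impression of the carboxy-ended members, whereas this pair shows that the end of the chain can by itself move the number substantially on the shared core, with one hydrogen-bond donor and a second double bond outside the aromatic rings entering together. No available evidence explains the size of this step.

Among these compounds, how the step divides between loss of the ethyl ester and gain of the but-3-enyl branch stays open, since both arrive in the one change. A carboxymethyl end without a branch and a 1-carboxybutyl group, with its saturated propyl branch, would separate those two parts, and an ethyl ester carrying the same but-3-enyl branch would test the branch with the ester kept.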